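A few compounds are considered here, and "the series" means these few. Any claim that something is new, unique, unknown or untested is made for them only; others in the source may bear on it.

Compound 1 `CC(CCc1ccc(OCc2ccc3ccccc3n2)cc1)Cc1nnn[nH]1` gives 25 nM in an assay on membranes from lung (Cavia porcellus) for binding affinity to cysteinyl leukotriene receptor (Homo sapiens); a higher number here means a weaker inhibitor, a lower number a stronger inhibitor.
Compound 2 `CC(CCC(=O)O)Cc1cccc(OCc2ccc3ccccc3n2)c1` gives 140 nM in this assay.
Compound 3 `O=C(O)CCC(Cc1cccc(OCc2ccc3ccccc3n2)c1)c1ccccc1` gives 52 nM in this assay.

Compound 2 stands at the highest number of the three in this assay; compound 3 lies nearer to it and compound 1 further below. Compound 4 `CC(CCCc1cccc(OCc2ccc3ccccc3n2)c1)C(=O)O` differs from compound 2 by 3-carboxybutyl in place of 3-carboxy-1-methylpropyl on a saturated chain carbon bound to an aromatic carbon: the same atoms, with the methyl shifted along the chain. Within the data shown here, the only single-change step measured, a 2.7-fold lower number from compound 2 to compound 3 (0.43 log units; beyond the scatter), swaps methyl for phenyl at the same chain carbon rather than moving a group, so it bears only loosely on this change. Among the measured compounds shown here, no measured step tracks such a shift, so compound 4 is expected to move little, with a 1.2-fold lower number from compound 2 to compound 4 (0.07 log units; within the scatter) estimated to fall within the scatter. Compound 4 is therefore estimated at 120 nM, within a range from 45 nM to 350 nM.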

Compound 4, inhibition constant: 85 nM
Compound 4: middle estimate off by 1.4-fold (0.15 log units), on the high side; the range from low to high includes it.
By their numbers in this assay, from the lowest: compound 1; then compounds 3, 4 and 2 (each within the scatter of the next, the first and the last beyond it).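

In this assay, the shift of the methyl along the chain gives a 1.6-fold lower number from compound 2 to compound 4 (0.22 log units; within the scatter), so compound 2 and compound 4 cannot be told apart. The earlier step, a 2.7-fold lower number from compound 2 to compound 3 (0.43 log units; beyond the scatter), showed a change of group; this one shows that rearranging the same atoms, with 3-carboxybutyl in place of 3-carboxy-1-methylpropyl, produces no readable difference. No supporting data bear on the reason for this result. From the compounds shown here alone, it remains open how an ethyl group on this chain, or a longer chain ending in the carboxylic acid, would read in this assay.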